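A few compounds are considered here, and "the series" means these few. Any claim that something is new, unique, unknown or untested is made for them only; others in the source may bear on it.

Compound 1 `O=C(NCCN1CCCc2ccccc21)c1ccc(OC(F)(F)F)cc1` and compound 2 `O=C(NCCC1CCCc2ccccc21)c1ccc(OC(F)(F)F)cc1` share the same amide and the same trifluoromethoxy-bearing ring; the difference between their two cores is not broken down here. In a functional assay on HEK293 cells for antagonist activity at transient receptor potential cation channel subfamily V member 1 (Homo sapiens), read by calcium flux (a lower number here means a stronger inhibitor, a higher number a weaker inhibitor), compound 1 gives 4600 nM, and compound 2 gives 5400 nM; the two numbers lie within the scatter of each other, so nothing separates them. Compound 3 `O=C(NCCN1CCCc2ccc(O)cc21)c1ccc(OC(F)(F)F)cc1` is compound 1 with one change, (hydroxy in place of hydrogen on an aromatic carbon), and in this assay compound 3 gives 960 nM, a step of a 4.8-fold lower number from compound 1 to compound 3 (0.68 log units; beyond the scatter). Compound 4 `O=C(NCCC1CCCc2ccc(O)cc21)c1ccc(OC(F)(F)F)cc1` carries the same change on the core of compound 2, (hydroxy in place of hydrogen on an aromatic carbon), at a place described in the same words as for compound 3. Compound 4 has not yet been measured. Its step from compound 2 is expected to be a 4.9-fold lower number from compound 2 to compound 4 (0.69 log units; beyond the scatter), close to the earlier one, because a 4.8-fold lower number from compound 1 to compound 3 (0.68 log units; beyond the scatter) was seen for the same change on the closely related core of compound 1. On that basis compound 4 is estimated at 1100 nM in this assay, most likely between 450 nM and 2800 nM.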

Compound 4, half-maximal inhibitory concentration: 1350 nM
Compound 4: middle estimate off by 1.2-fold (0.09 log units), on the low side; the measured number falls inside the stated range.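

In this assay, hydroxy in place of hydrogen on an aromatic carbon gives a step of a 4.0-fold lower number from compound 2 to compound 4 (0.60 log units; beyond the scatter), so the change also lowers the number on this second core. Set beside the step on the core of compound 1, the size of the change holds across the two cores: the same change on two cores in this assay, a 4.8-fold lower number (0.68 log units; beyond the scatter) from compound 1 to compound 3 and a 4.0-fold lower number (0.60 log units; beyond the scatter) from compound 2 to compound 4, 1.2-fold (0.08 log units) apart, within the scatter of two such steps This shows that the step carried over between these two closely related cores, but it rests on only two pairs, so it does not show that the step would carry over to any other core, and it gives no reason why the hydroxy group lowers the number.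

The compounds shown leave open whether a methoxy group or a fluorine atom in the same place would give a similar step, and whether a hydroxy group elsewhere on the aromatic ring would do so. They also leave open whether the step would survive a trifluoromethyl group in place of trifluoromethoxy, or a longer chain linking the amide to the core.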